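Shortening the sulfonamide linker on a shared quinazoline-free core

The compounds below may be only part of what the source reports. "The series", "measured", "known", "first", "only" and "open" are said of these compounds alone.

Measured so far:
compound 1, `Cc1nc(NCCNC(=O)C2CC2)nc2ccc(NC(=O)/C=C/c3ccc(OC(F)(F)F)cc3)cc12`, 61 nM
compound 2, `Cc1nc(NCCCNS(C)(=O)=O)nc2ccc(NC(=O)/C=C/c3ccc(OC(F)(F)F)cc3)cc12`, 54 nM

Both compounds were tested in an assay on CHO-K1 cells for displacement of a labelled ligand from melanin-concentrating hormone receptor 1 (Homo sapiens), read by scintillation proximity assay, with a stated time of 2 h; on this read-out higher numbers stand for weaker inhibition and lower numbers for stronger inhibition. Compound 1 gives 61 nM and compound 2 gives 54 nM, so on these two numbers compound 2 stands at the lower of the two, but the step of a 1.1-fold lower number from compound 1 to compound 2 (0.05 log units; within the scatter) is within the scatter and the two compounds cannot be told apart.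

Compound 3, `Cc1nc(NCCNS(C)(=O)=O)nc2ccc(NC(=O)/C=C/c3ccc(OC(F)(F)F)cc3)cc12`, is not yet measured. It differs from compound 2 by methanesulfonamido in place of (methanesulfonamido)methyl on a saturated chain carbon, two bonds along the chain from a nitrogen on an aromatic ring. Among the measured compounds shown here, the only measured step, a 1.1-fold lower number from compound 1 to compound 2 (0.05 log units; within the scatter), exchanges the group on that chain carbon and does not shorten the chain, so it bears on the new change only loosely: it shows that this part of the molecule tolerated one alteration without a shift beyond the scatter. Nothing in the data speaks to the chain length itself. Compound 3 is therefore expected to stay close to compound 2, with a step of a 1.3-fold higher number from compound 2 to compound 3 (0.11 log units; within the scatter) in this assay that is expected to fall within the scatter. The estimate for compound 3 is 70 nM, with a range from 25 nM to 200 nM.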

Compound 3, half-maximal inhibitory concentration: 169 nM
Beside the measured number, compound 3's estimate is 2.4-fold (0.38 log units) below it, and the stated range covers the measured number.
By their numbers in this assay, from the lowest: compounds 2 and 1 (each within the scatter of the next); then compound 3.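

In this assay, among the compounds shown here, the length of the chain carrying the sulfonamide proves to matter: going from 3-(methanesulfonamido)propyl to 2-(methanesulfonamido)ethyl gives a 3.1-fold higher number from compound 2 to compound 3 (0.50 log units; beyond the scatter), the first step beyond the scatter. With the chain left unchanged, methylsulfonyl in place of cyclopropylcarbonyl on an amine nitrogen gives a 2.8-fold higher number from compound 1 to compound 3 (0.44 log units; beyond the scatter), so the end group matters as well, and the earlier step, a 1.1-fold lower number from compound 1 to compound 2 (0.05 log units; within the scatter), is now seen to combine a change of chain length with a change of end group, although each change alone gives a step beyond the scatter. Nothing in the available data explains either new step.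

The compounds shown leave open how the cyclopropylcarbonyl group behaves on the propyl chain, and whether a longer chain, such as a butyl chain ending in methanesulfonamido, would lower the number further or raise it. They also leave open whether the chain tolerates other end groups, such as an amine or a carboxylic acid.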